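Amide group swap on the shared core: pyrrolidin-1-yl to piperazin-1-yl

The source may report more compounds than this note shows. Statements on the series, on what has been measured and on what is new or still open speak of the compounds shown alone.

In a functional assay on A549 cells (Homo sapiens) for inhibition, read by sulforhodamine B assay, with a stated time of 72 h (on this read-out lower numbers stand for stronger inhibition and higher numbers for weaker inhibition), compound 1 (`Nc1sc(-c2ccc(Cl)cc2)c(-c2ccc(Cl)cc2)c1C(=O)NC1CCCCC1`), with cyclohexylamino on the carbonyl carbon, gives 2410 nM as its value. Compound 2 (`Nc1sc(-c2ccc(Cl)cc2)c(-c2ccc(Cl)cc2)c1C(=O)Nc1ccccc1`), with anilino on that carbon, gives 25000 nM on the same read-out. Compound 3 (`Nc1sc(-c2ccc(Cl)cc2)c(-c2ccc(Cl)cc2)c1C(=O)N1CCCC1`), with pyrrolidin-1-yl on that carbon, gives 890 nM and so holds the lowest of the three numbers, beyond the scatter from both others.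

Compound 4 (`Nc1sc(-c2ccc(Cl)cc2)c(-c2ccc(Cl)cc2)c1C(=O)N1CCNCC1`) carries piperazin-1-yl in place of pyrrolidin-1-yl on a carbonyl carbon.

All three measured steps concern this same carbonyl carbon. The closest comparison, with no aromatic group on either side, is a 2.7-fold lower number from compound 1 to compound 3 (0.43 log units; beyond the scatter) and counts as modest. The two steps involving compound 2, a 28-fold lower number from compound 2 to compound 3 (1.45 log units; beyond the scatter) and a 10-fold higher number from compound 1 to compound 2 (1.02 log units; beyond the scatter), are both large and have an aromatic group on one side. For the measured compounds named here, no measured compound carries a second ring nitrogen, so the direction rests on thin evidence. A modest step towards a higher number is expected, and the large steps are not taken as a guide. In this assay the expected outcome is a 2.2-fold higher number from compound 3 to compound 4 (0.35 log units; beyond the scatter) in this estimate. For compound 4 the estimated value is 2000 nM with an expected range of 600 nM to 6500 nM in this read-out.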

Compound 4, half-maximal inhibitory concentration: 1020 nM
Estimate against measurement, compound 4: 2.0-fold (0.29 log units) above, and the stated range covers the measured number.
By their numbers in this assay, from the lowest: compounds 3 and 4 (each within the scatter of the next); then compound 1; then compound 2.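

In this assay the swap of pyrrolidin-1-yl for piperazin-1-yl on the carbonyl carbon reads as a 1.1-fold higher number from compound 3 to compound 4 (0.06 log units; within the scatter) and so gives no separation between the two rings, even though the entering group brings 1 hydrogen-bond donor and 1 hydrogen-bond acceptor where the leaving group has none. Compound 4 also stands clear of both amides that keep the amide hydrogen, with a 25-fold lower number from compound 2 to compound 4 (1.39 log units; beyond the scatter) and a 2.4-fold lower number from compound 1 to compound 4 (0.37 log units; beyond the scatter) in the same assay, so among these four compounds the two ring amides without that hydrogen hold the lower numbers and none goes against this. No measurement on these groups is available that would account for this result.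

Open, as far as these compounds go, is whether the tolerance at this position extends to morpholin-4-yl or 4-methylpiperazin-1-yl, or to an open-chain group such as dimethylamino. Also open, from the compounds shown here alone, is whether a larger group on the second ring nitrogen of piperazin-1-yl, such as an acetyl or a benzyl, keeps compound 4's standing against compound 3 on the shared core.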